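The compounds below may be only part of what the source reports. "The series", "measured", "known", "first", "only" and "open" are said of these compounds alone.

The three measured compounds share one core and differ only in the aryl group on the carbonyl carbon. In a functional assay on RXF 393 cells (Homo sapiens) for inhibition, read by sulforhodamine B assay, with a stated time of 48 h (on this read-out lower numbers stand for stronger inhibition of growth and higher numbers for weaker inhibition of growth), compound 1 `COc1cc(-c2cc(/C=C/C(=O)c3ccc(N)cc3)[nH]n2)cc(OC)c1OC` gives 1350 nM, compound 2 `COc1ccc(C(=O)/C=C/c2cc(-c3cc(OC)c(OC)c(OC)c3)n[nH]2)cc1OC` gives 1350 nM, and compound 3 `COc1ccc(C(=O)/C=C/c2cc(-c3cc(OC)c(OC)c(OC)c3)n[nH]2)cc1` gives 1270 nM. The steps among them are small: no change at the digits printed from compound 1 to compound 2 (within the scatter), a 1.1-fold lower number from compound 1 to compound 3 (0.03 log units; within the scatter) and a 1.1-fold lower number from compound 2 to compound 3 (0.03 log units; within the scatter). Compound 3 thus stands within the scatter of both compound 1 and compound 2, and no one of the three can be set apart from the others.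

Compound 4 `COc1cc(-c2cc(/C=C/C(=O)c3ccc(F)c(F)c3)[nH]n2)cc(OC)c1OC` is reached from compound 3 by the change (3,4-difluorophenyl in place of 4-methoxyphenyl on a carbonyl carbon). Going by the values given here, the steps that bear on it are the aryl exchange from compound 1 to compound 2 and the methoxy changes from compound 1 to compound 3 and from compound 2 to compound 3, each of which stayed within the scatter. On that basis the step from compound 3 to compound 4 is expected to be a 1.0-fold higher number from compound 3 to compound 4 (0.01 log units; within the scatter), with no shift beyond the scatter in this assay. Compound 4 is therefore estimated at 1300 nM, within a range from 600 nM to 2800 nM.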

Compound 4, concentration for 50% growth inhibition: 2050 nM
The estimate for compound 4 lay 1.6-fold (0.20 log units) below the measured number; low and high end bracket the measured number.
By their numbers in this assay, from the lowest: compounds 3, 1, 2 and 4 (each within the scatter of the next).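

In this assay the 3,4-difluorophenyl group on the carbonyl carbon stays within the scatter of each of the three aryl groups before it, whether it replaces 4-methoxyphenyl (a 1.6-fold higher number from compound 3 to compound 4 (0.21 log units; within the scatter)), 3,4-dimethoxyphenyl (a 1.5-fold higher number from compound 2 to compound 4 (0.18 log units; within the scatter)) or 4-aminophenyl (a 1.5-fold higher number from compound 1 to compound 4 (0.18 log units; within the scatter)). The earlier compounds had shown this only for aryl groups bearing methoxy or amino, and the position now also holds a ring bearing fluorine with no step beyond the scatter. Nothing available gives a reason for the size of these steps.

The compounds shown leave open whether this position stays as flat with a carboxylic acid or a longer chain on the phenyl ring. They also leave open how a phenyl ring with a single fluorine or a trifluoromethyl group would read here, and whether any aryl group at this carbonyl carbon can move the number beyond the scatter.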